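The source may hold more compounds than are shown below. What is called first, only, known or untested is meant among the compounds shown, and "the series" means these compounds.

In a functional assay on the whole organism (B cells) with Mus musculus as the target (on this read-out lower numbers stand for smaller maximal responses and higher numbers for larger maximal responses), compound 1 `Nc1nc(O)c2c(n1)n(C1OC(CO)[C@@H](O)[C@H]1O)c(=O)n2CC(O)CO` gives 136%, the highest of the two numbers recorded so far. Its nearest neighbour is compound 2 `C=CCn1c(=O)n(CCCCCCCC)c2nc(N)nc(O)c21`, which gives 130% in this assay, a number that lies within the scatter of compound 1, so the two cannot be placed in any order. Among the measured compounds shown here, these two compounds differ in several places at once, and no step between them is counted, so the measured pair says nothing about any single change.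

The compound now in question, compound 3 `Nc1nc(O)c2c(n1)n(C1OC(CO)[C@@H](O)[C@H]1O)c(=O)n2CCN1CCCCC1`, is reached from compound 1 by one change: (piperidin-1-yl)methyl in place of 1,2-dihydroxyethyl on a saturated chain carbon bound to an aromatic nitrogen. For the measured compounds named here, no measured pair shows what this change does to the maximal response in this assay.

With both measured compounds giving numbers of about the same size, the step of a number 11 percentage points lower from compound 1 to compound 3 (beyond the scatter) is estimated to be small, with no clear direction beyond the scatter. Compound 3 is therefore expected to give 125% in this assay, with a range from 95% to 155% that reflects the absence of any measured step for this change.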

Compound 3, largest response reached (reported as maximal response), in percent of the reference or control that the assay uses: 0%
Compound 3: middle estimate off by 125 percentage points, on the high side; the whole stated range lies above it.
By their numbers in this assay, from the lowest: compound 3; then compounds 2 and 1 (each within the scatter of the next).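

In this assay, putting (piperidin-1-yl)methyl in place of 1,2-dihydroxyethyl on a saturated chain carbon bound to an aromatic nitrogen gives a large step, a number 136 percentage points lower from compound 1 to compound 3 (beyond the scatter), and this is the only step shown that isolates a single change. The earlier pair differed in several places at once and could say nothing about any one place, whereas this result shows that the maximal response depends strongly on what this place carries, even with the rest of compound 1 left intact. Nothing at hand bears on why the response is lost at this change.

The step removes 1,2-dihydroxyethyl and brings in (piperidin-1-yl)methyl together, so the compounds shown cannot tell whether the loss goes with the group that leaves, the group that enters, or both. On these data alone, it also remains open what a 2-(dimethylamino)ethyl group, a 2-(morpholin-4-yl)ethyl group, a 2-hydroxyethyl group or a plain butyl chain would give in this place, and therefore whether the response falls gradually or only with the piperidine ring.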